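This account rests on a few compounds, and the source may have more. Where it says the series, first, only, none or still open, it means among the compounds named here.

In an assay on CHO cells for displacement of a labelled ligand from Substance-P receptor (Homo sapiens), with a stated time of 90 min (a higher number here means a weaker inhibitor, a lower number a stronger inhibitor), compound 1 `Cc1nc2ccccc2c(-c2ccccc2)c1C(=O)N(C)Cc1cc(C(F)(F)F)cc(C(F)(F)F)c1` gives 19 nM. Compound 2 `Cc1c(C(=O)NCc2cc(C(F)(F)F)cc(C(F)(F)F)c2)c(-c2ccccc2)cc2nnnn12` gives 279 nM in this assay, the higher of the two numbers and so the weaker inhibitor. Compound 3 `Cc1c(C(=O)N(C)Cc2cc(C(F)(F)F)cc(C(F)(F)F)c2)c(-c2ccccc2)cc2nnnn12` keeps the core of compound 2 and differs from it only by methyl in place of hydrogen on an amide-type nitrogen. For the measured compounds named here, no measured pair shows this same change. Compound 1, which carries a methyl on its amide nitrogen, gives 19 nM, the lower number, so a step toward a lower number is expected for compound 3. The expected step from compound 2 to compound 3 is a 9.3-fold lower number from compound 2 to compound 3 (0.97 log units; beyond the scatter). For compound 3 the estimate in this assay is 30 nM, within a range from 8 nM to 120 nM.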

Compound 3, half-maximal inhibitory concentration: 57 nM
For compound 3 the middle estimate is 1.9-fold (0.28 log units) below the measured one, within the range that was stated.
By their numbers in this assay, from the lowest: compound 1; then compound 3; then compound 2.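

Putting methyl in place of the amide hydrogen gives, in this assay, a 4.9-fold lower number from compound 2 to compound 3 (0.69 log units; beyond the scatter), a modest step that is beyond the usual scatter. For the compounds shown here, this is the first direct pair for this change, and it shows that on this shared core the amide-type nitrogen need not keep its hydrogen for the number to fall. Nothing measured here explains the step. From the compounds shown here alone, whether an ethyl group or a longer chain on this nitrogen would lower the number further remains open, as does the size of the same step on the core of compound 1.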